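Compound 2 to compound 3: furan swapped for indole

The source may report more compounds than this note shows. Statements on the series, on what has been measured and on what is new or still open speak of the compounds shown alone.

In a physicochemical assay for solubility, read by spectrophotometry, in phosphate buffer, with a stated time of 2 h, at pH 7.4 (on this read-out lower numbers stand for lower solubility and higher numbers for higher solubility), compound 1 (`O=C(c1cc2cc(C3CC3)ccc2[nH]1)N1CC(=O)N(Cc2ccccc2)[C@@H](CN2CCN(Cc3ccccc3)CC2)C1`) gives 12900 nM and compound 2 (`COc1ccc2[nH]c(C(=O)N3CC(=O)N(Cc4ccoc4)[C@@H](Cc4ccccc4)C3)cc2c1`) gives 63600 nM as the higher of the two numbers, a gap beyond the scatter. Compound 3 (`COc1ccc2[nH]c(C(=O)N3CC(=O)N(Cc4cc5ccccc5[nH]4)[C@@H](Cc4ccccc4)C3)cc2c1`) differs from compound 2 by 1H-indol-2-yl in place of furan-3-yl on a saturated chain carbon bound to an amide-type nitrogen in a ring on a saturated chain carbon bound to an amide-type nitrogen in a ring. Going by the values given here, no measured pair shows a change of this kind, so the call rests on judgement alone. A fall beyond the scatter is expected in this assay and is estimated as a 4.2-fold lower number from compound 2 to compound 3 (0.63 log units; beyond the scatter) here. Compound 3 is estimated at 15000 nM (range 4000 nM to 45000 nM).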

Compound 3, solubility: 11000 nM
Beside the measured number, compound 3's estimate is 1.4-fold (0.13 log units) above it; measured number inside the range.
By their numbers in this assay, from the lowest: compounds 3 and 1 (each within the scatter of the next); then compound 2.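

In this assay, the position on a saturated chain carbon bound to an amide-type nitrogen in a ring responds to its substituent: 1H-indol-2-yl in place of furan-3-yl gives a 5.8-fold lower number from compound 2 to compound 3 (0.76 log units; beyond the scatter). Going by these compounds alone, this is the only single-place step so far, and it is one data point. The change brings in a six-membered aromatic ring of carbon only and a hydrogen-bond donor together, and nothing available gives a cause for the step.

Open, on these data alone, is how an amine or a carboxylic acid at this place would read. Also open, as far as these compounds go, is whether the step holds on another core.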